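An Unmeasured Lactam Analog in a Receptor Agonist Series

A few compounds are considered here, and "the series" means these few. Any claim that something is new, unique, unknown or untested is made for them only; others in the source may bear on it.

The account follows compound 1 `CCc1cnc(N2CCC(c3nc(COc4ccc(/C=C5\CC(=S)N(CC(=O)O)C5=O)cc4F)cs3)CC2)nc1` to compound 4 `CCc1cnc(N2CCC(c3nc(COc4ccc(/C=C5\CCNC5=O)cc4F)cs3)CC2)nc1` in a functional assay on cells for agonist activity at Glucose-dependent insulinotropic receptor (Homo sapiens), read by a luciferase reporter, with a stated time of 6 h; on this read-out lower numbers stand for an effect already at smaller amounts and higher numbers for an effect only at larger amounts of compound. For compound 1 the entry in this assay reads "not determined" (no result reported), so no single number exists there. One further compound, compound 2 `CC(C)(C)OC(=O)N1CCC(c2nc(COc3c(F)cc(/C=C4\CC(=O)NC4=O)cc3F)cs2)CC1`, is likewise without a result there: for compound 2 the entry reads "not determined" (no result reported). Within the data shown here, the only number comes from compound 3 `CC(C)(C)OC(=O)N1CCC(c2nc(COc3ccc(-n4cnnn4)cc3)cs2)CC1`, which in this assay gives 103 nM. Compound 4 arises from compound 1 through a change on an aromatic carbon: a group of 7 heavy atoms (5 carbon, 1 nitrogen, 1 oxygen; one five-membered non-aromatic ring with 1 hetero atom) in place of a group of 12 heavy atoms (7 carbon, 1 nitrogen, 3 oxygen, 1 sulfur; one five-membered non-aromatic ring with 1 hetero atom), on an aromatic carbon. No step between measured compounds is available, so the size and direction of the move from compound 1 to compound 4 in this assay cannot be drawn from the numbers shown, and whether it exceeds the scatter remains open. On this footing compound 4 is expected to give about 200 nM, within an estimated range from 30 nM to 2000 nM.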

Compound 4, half-maximal effective concentration: 100 nM
Compound 4: middle estimate off by 2.0-fold (0.30 log units), on the high side; low and high end bracket the measured number.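

No step can be read in this assay between compound 1 and compound 4, or from compound 4 to any other compound. The compounds shown leave open how far exchanging the group on the aromatic carbon moves this read-out, and no information on a cause is available.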